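This account rests on a few compounds, and the source may have more. Where it says the series, first, only, none or still open, it means among the compounds named here.

The measured compounds are compound 1 `O=C(NC1(c2ccc3c(n2)CCN3c2ccnc(C(F)(F)F)n2)CCC1)c1ccc(Cl)cc1` with 93 nM, compound 2 `CCN(C(=O)N1CCc2cc(C3(C(=O)Nc4ccc(Cl)cc4)CCC3)ccc21)C(C)C` with 3.3 nM, and compound 3 `O=C(NC1(c2ccc3c(n2)CCN3C(=O)OC2CC2)CCC1)c1ccc(Cl)cc1` with 4.5 nM, all in an assay on HeLa cells for inhibition of Indoleamine 2,3-dioxygenase 1 (Homo sapiens); on this read-out higher numbers stand for weaker inhibition and lower numbers for stronger inhibition.

Compound 1 gives the highest number of the three, so it is the weakest inhibitor here. Among the measured compounds shown here, the one single-point step recorded is a 21-fold lower number from compound 1 to compound 3 (1.32 log units; beyond the scatter), a change made on a nitrogen on an aromatic ring in a ring, far from the position altered in the new compound.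

Compound 4 `O=C(Nc1ccc(F)cc1)C1(c2ccc3c(n2)CCN3c2ccnc(C(F)(F)F)n2)CCC1` differs from compound 1 in one place: (4-fluorophenyl)carbamoyl in place of ((4-chlorophenyl)carbonyl)amino on a saturated ring carbon. For the measured compounds named here, no measured pair differs in exactly this way, so no step speaks to it directly. Compound 2 carries a (4-chlorophenyl)carbamoyl group on a comparable ring carbon and gives a low number, but it also differs from compound 1 in other parts, so its value cannot be read as the effect of this one change.

With nothing directly comparable, the expected step of a 1.3-fold higher number from compound 1 to compound 4 (0.11 log units; within the scatter) is small, in no certain direction, and may stay within the scatter. Compound 4 is therefore estimated at 120 nM in this assay, within a range from 30 nM to 500 nM.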

Compound 4, half-maximal inhibitory concentration: 127 nM
Beside the measured number, compound 4's estimate is 1.1-fold (0.02 log units) below it, and the stated range covers the measured number.
By their numbers in this assay, from the lowest: compounds 2 and 3 (each within the scatter of the next); then compounds 1 and 4 (each within the scatter of the next).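

The swap of ((4-chlorophenyl)carbonyl)amino for (4-fluorophenyl)carbamoyl on a saturated ring carbon of a four-membered non-aromatic ring of carbon only gives, in this assay, a 1.4-fold higher number from compound 1 to compound 4 (0.14 log units; within the scatter). Among the compounds shown here, no earlier pair spoke to this position, and this one shows that the read-out stays within the usual scatter even though the amide is turned round, with its carbonyl rather than its nitrogen now on the ring carbon, and fluorine takes the place of chlorine on the phenyl ring. These two alterations arrive together, so the step cannot tell whether each one alone leaves the number unchanged or whether they offset each other, and no supporting measurement is available to explain the outcome.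

Still open, as far as these compounds go, is how each alteration behaves alone, for instance with (4-chlorophenyl)carbamoyl on the core of compound 1 in place of (4-fluorophenyl)carbamoyl. The compounds shown also leave open what a quite different group on this ring carbon, such as a carboxylic acid or an amine, would do to the number.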